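The source may report more compounds than this note shows. Statements on the series, on what has been measured and on what is new or still open speak of the compounds shown alone.

Series notes. Compound 1 `ClCc1ccc(Cn2cnc3c(Cl)ncnc32)cc1` and compound 3 `ClCc1ccccc1Cn1cnc2c(Cl)ncnc21` are built from the same atoms joined differently; the difference between the two cores is not broken down here. In a functional assay on SN12C cells (Homo sapiens) for cytotoxicity, read by sulforhodamine B assay, with a stated time of 48 h (on this read-out higher numbers stand for weaker inhibition of growth and lower numbers for stronger inhibition of growth), compound 1 gives 1020 nM. In this assay, for the measured compounds named here, compound 3 gives 3380 nM, the second highest of the three numbers known so far. Compound 2 `Nc1nc(Cl)c2ncn(Cc3ccc(CCl)cc3)c2n1` carries, on the core of compound 1, (amino in place of hydrogen on an aromatic carbon). In this assay compound 2 gives 12300 nM, which is a 12-fold higher number from compound 1 to compound 2 (1.08 log units; beyond the scatter). Compound 4 `Nc1nc(Cl)c2ncn(Cc3ccccc3CCl)c2n1` carries the corresponding change on the core of compound 3, (amino in place of hydrogen on an aromatic carbon). The surroundings of the change are described in the same words for both pairs, so it counts as the same change, not merely the same kind. Compound 4 is expected to show a 10-fold higher number from compound 3 to compound 4 (1.02 log units; beyond the scatter) in this assay, a step in the same direction and of roughly the size seen in a 12-fold higher number from compound 1 to compound 2 (1.08 log units; beyond the scatter). Going by the values given here, the range is kept wide because a 12-fold higher number from compound 1 to compound 2 (1.08 log units; beyond the scatter) is the single precedent for this change. The estimate for compound 4 is 35000 nM, with a likely span from 12000 nM to 100000 nM.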

Compound 4, concentration for 50% growth inhibition: 2750 nM
The estimate for compound 4 lay 13-fold (1.10 log units) above the measured number; the measured number lies below the stated range.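

Amino in place of hydrogen on an aromatic carbon does not carry over from one core to the other in this assay: the same change on two cores in this assay, a 12-fold higher number (1.08 log units; beyond the scatter) from compound 1 to compound 2 and a 1.2-fold lower number (0.09 log units; within the scatter) from compound 3 to compound 4, 15-fold (1.17 log units) apart, beyond the scatter of two such steps. On the core of compound 3 the change gives a 1.2-fold lower number from compound 3 to compound 4 (0.09 log units; within the scatter), so no effect of the amino group can be read on this core, whereas the core of compound 1 gives a 12-fold higher number from compound 1 to compound 2 (1.08 log units; beyond the scatter). The outcome of this change therefore differs between these two cores, but two pairs do not show why, and they give no rule for predicting the step on a further core.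

Open, going by these compounds, is whether a methylamino group or a hydroxyl group on the same aromatic carbon would also give different steps on the two cores. Also open, on these data alone, is how the numbers on either core would respond to a methyl group in place of the chloromethyl group.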